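Pyridin-4-yl in Place of the Alkyne: Expected Clearance

The compounds below may be only part of what the source reports. "The series", "measured", "known", "first", "only" and "open" are said of these compounds alone.

Compound 1 `Nc1ccc(S(=O)(=O)N2CCN(c3ncc(C(O)(C(F)(F)F)C(F)(F)F)cc3C#CC3CC3)CC2)cn1` in an ADME assay (liver) for metabolic stability, with Liver microsome (Homo sapiens) as the target, using microsomes and NADPH, with a stated time of 30 min, tested at 1 uM; a lower number here means slower removal, a higher number faster removal of the compound: < 14 mL.min-1.g-1
Compound 2 `CC(C)(O)C#Cc1cc(C(O)(C(F)(F)F)C(F)(F)F)cnc1N1CCN(S(=O)(=O)c2ccc(N)nc2)CC1` in this assay: < 14 mL.min-1.g-1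
Compound 3 `CC(C)(C)n1cc(-c2cc(C(O)(C(F)(F)F)C(F)(F)F)cnc2N2CCN(S(=O)(=O)c3ccc(N)nc3)CC2)cn1` in this assay: 86 mL.min-1.g-1

In this assay compound 1 gives < 14 mL.min-1.g-1, which is a limit of the assay rather than a number. Compound 2 likewise gives < 14 mL.min-1.g-1, again a limit. Compound 3 gives 86 mL.min-1.g-1. The step of an at least 6.1-fold higher number from compound 1 to compound 3 (0.78 log units; beyond the scatter) and the step of an at least 6.1-fold higher number from compound 2 to compound 3 (0.78 log units; beyond the scatter) both show that putting 1-(tert-butyl)-1H-pyrazol-4-yl on the aromatic carbon in place of the triple-bonded groups raises the number. The step that the two limits leave unreadable from compound 1 to compound 2 cannot be read because the limit of < 14 mL.min-1.g-1 in this assay, at which 2 of the 3 values shown sit, holds both values.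

Compound 4 `Nc1ccc(S(=O)(=O)N2CCN(c3ncc(C(O)(C(F)(F)F)C(F)(F)F)cc3-c3ccncc3)CC2)cn1` differs from compound 1 by pyridin-4-yl in place of 2-cyclopropylethynyl on an aromatic carbon. Going by the values given here, the only measured guide is the step of an at least 6.1-fold higher number from compound 1 to compound 3 (0.78 log units; beyond the scatter), where an aromatic ring also replaced 2-cyclopropylethynyl; pyridin-4-yl carries no tert-butyl, so a rise in this assay is expected, but of smaller size. Compound 4 is thus expected to move by an at least 1.7-fold higher number from compound 1 to compound 4 (0.25 log units; that floor lies within the scatter). Compound 4 is therefore estimated at 25 mL.min-1.g-1, within 10 mL.min-1.g-1 to 60 mL.min-1.g-1.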

Compound 4, intrinsic clearance in microsomes: 15 mL.min-1.g-1
For compound 4 the middle estimate is 1.7-fold (0.22 log units) above the measured one; the range from low to high includes it.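

Pyridin-4-yl in place of 1-(tert-butyl)-1H-pyrazol-4-yl on this aromatic carbon gives a 5.7-fold lower number from compound 3 to compound 4 (0.76 log units; beyond the scatter) in this assay, so an aromatic ring here does not by itself bring the high number of compound 3. Against the two triple-bonded groups, the change shows only an at least 1.0-fold higher number from compound 1 to compound 4 (0.02 log units; that floor lies within the scatter) and an at least 1.0-fold higher number from compound 2 to compound 4 (0.02 log units; that floor lies within the scatter), and neither floor establishes a rise. The true size of these two steps cannot be read because compounds 1 and 2 sit at a limit of the assay: the limit of < 14 mL.min-1.g-1 in this assay, at which 2 of the 4 values shown sit.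

From the compounds shown here alone, whether a 1-methyl-1H-pyrazol-4-yl group at this position would stay near compound 4 or move towards compound 3 remains open. Also open, going by these compounds, is how a pyridin-3-yl ring would compare with pyridin-4-yl on the same carbon.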